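The source may hold more compounds than are shown below. What is called first, only, known or untested is meant among the compounds shown, and "the series" means these compounds.

Compound 1 `CCCN(CC[C@H]1CC[C@H](NC(=O)/C=C/c2cccc(Cl)c2)CC1)[C@H]1CCc2nc(N)sc2C1` carries a 3-chlorophenyl group on an acrylamide and, in an assay on brain for displacement of a labelled ligand from D(3) dopamine receptor (Rattus norvegicus) (on this read-out higher numbers stand for weaker inhibition and lower numbers for stronger inhibition), compound 1 gives 1.2 nM. Compound 2 `CCCN(CC[C@H]1CC[C@H](NS(=O)(=O)c2cccc3ccccc23)CC1)[C@H]1CCc2nc(N)sc2C1` replaces that amide with a sulfonamide bearing a naphthalen-1-yl group, and in this assay compound 2 gives 1.5 nM. On the two numbers shown, compound 2 is not separated from compound 1: the gap between them lies within the usual scatter of repeated measurements, so neither can be called the stronger binder.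

Compound 3 `CCCN(CC[C@H]1CC[C@H](NS(=O)(=O)c2cccc(Cl)c2)CC1)[C@H]1CCc2nc(N)sc2C1` keeps the sulfonamide of compound 2 but alters the aryl group: 3-chlorophenyl in place of naphthalen-1-yl on a sulfonyl sulfur. Going by the values given here, no measured pair shows this change directly, so any expectation rests on the two measured numbers alone. Compound 1 already shows that a 3-chlorophenyl group on the shared core is compatible with a number such as 1.2 nM, though attached through a different linker. The step from compound 2 to compound 3 is therefore expected to be modest, a 2.0-fold higher number from compound 2 to compound 3 (0.30 log units; within the scatter), at most slightly toward a higher number. Compound 3 is estimated at 3 nM, with a plausible range of 1 nM to 10 nM.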

Compound 3, inhibition constant: 1.1 nM
Compound 3: the middle estimate sits 2.7-fold (0.44 log units) above what was measured, within the range that was stated.
By their numbers in this assay, from the lowest: compounds 3, 1 and 2 (each within the scatter of the next).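

In this assay, 3-chlorophenyl in place of naphthalen-1-yl on a sulfonyl sulfur gives a 1.4-fold lower number from compound 2 to compound 3 (0.13 log units; within the scatter), so at this position on the sulfonamide, one six-membered aromatic ring of carbon only with a chlorine is not separated from the two rings of naphthalen-1-yl. With the 3-chlorophenyl group now present on both sides, the linker can also be read on its own, something compound 1 and compound 2 did not allow, since they differ in both linker and aryl group: (3-chlorophenyl)sulfonyl in place of (2-(3-chlorophenyl)ethenyl)carbonyl on an amine nitrogen gives a 1.1-fold lower number from compound 1 to compound 3 (0.04 log units; within the scatter), so the sulfonamide and the acrylamide are not told apart here. The data shown contain nothing that explains how little these numbers move.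

On these data alone, all three compounds carry large aryl groups and lie within the scatter of one another, so it remains open how much of the aryl group this position needs, for instance whether a plain methyl on the sulfonyl sulfur would hold the number. As far as these compounds go, it also remains open whether a carboxylic acid or a primary amine on the phenyl ring would finally separate a compound from this group.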